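A Second Methoxy Group on the Shared Core

The source may hold more compounds than are shown below. What is called first, only, known or untested is meant among the compounds shown, and "the series" means these compounds.

Compound 1 `COc1ccc(-c2cc(=O)oc3ccccc23)cc1O` and compound 2 `COc1ccc(-c2cc(=O)oc3cccc(OC)c23)cc1O` share one core and differ in a single place. In a functional assay on K562 cells (Homo sapiens) for cytotoxicity, read by MTT assay, with a stated time of 48 h (a lower number here means a stronger inhibitor, a higher number a weaker inhibitor), compound 1 gives 92 nM, and compound 2 gives 86 nM. Among the compounds with values here, the step of a 1.1-fold lower number from compound 1 to compound 2 (0.03 log units; within the scatter) falls within the scatter, so the two numbers cannot be separated and compound 2 stands level with its only neighbour, compound 1.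

Compound 3 `COc1cc(OC)c2c(-c3ccc(OC)c(O)c3)cc(=O)oc2c1` has not yet been measured. It differs from compound 2 by methoxy in place of hydrogen on an aromatic carbon. Within the data shown here, the one measured step that bears on this change is a 1.1-fold lower number from compound 1 to compound 2 (0.03 log units; within the scatter), which brought the same kind of group onto the same ring and left the number essentially where it was. The expected step is therefore a 1.0-fold lower number from compound 2 to compound 3 (0.01 log units; within the scatter), nothing beyond the scatter. Compound 3 is expected to give 85 nM, with a likely range from 45 nM to 170 nM.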

Compound 3, half-maximal inhibitory concentration: 88 nM
Estimate against measurement, compound 3: 1.0-fold (0.02 log units) below; the range from low to high includes it.
By their numbers in this assay, from the lowest: compounds 2, 3 and 1 (each within the scatter of the next).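

The step of a 1.0-fold higher number from compound 2 to compound 3 (0.01 log units; within the scatter) in this assay shows that the shared core also accepts a methoxy group on this carbon, meta to a methoxy group and para to a fused ring. Compound 2 and compound 3 cannot be told apart, so the earlier finding for this kind of change, a 1.1-fold lower number from compound 1 to compound 2 (0.03 log units; within the scatter), is now matched at a second place on the same ring. Nothing shown here offers an explanation for this result.

Methoxy is the only group that enters in these steps, so the compounds shown leave open whether this carbon would accept any group in the same way. An amine, a carboxylic acid or a longer chain such as butoxy might give a number beyond the scatter, or might stand level with compound 3.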